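Swapping a para bromo for trifluoromethyl in a rat assay

A few compounds are considered here, and "the series" means these few. Any claim that something is new, unique, unknown or untested is made for them only; others in the source may bear on it.

Of the compounds shown here, three sharing one core have been measured in a functional assay on the whole organism for inhibition, with Rattus norvegicus as the target; a lower number here means that less compound is needed, a higher number that more compound is needed for the effect. Compound 1 `CC1CC/C(=N\Nc2cccc(Cl)c2)c2ncc(C(=O)O)c(=O)n21` gives 0.6 umol/kg. Compound 2 `CC1CC/C(=N\Nc2cccc(Br)c2)c2ncc(C(=O)O)c(=O)n21` gives 0.4 umol/kg. Compound 3 `CC1CC/C(=N\Nc2ccc(Br)cc2)c2ncc(C(=O)O)c(=O)n21` gives 0.8 umol/kg, the highest of the three numbers, though its gap to each neighbour is small: a 1.3-fold higher number from compound 1 to compound 3 (0.12 log units; within the scatter), and a 2.0-fold higher number from compound 2 to compound 3 (0.30 log units; within the scatter). The remaining measured step, a 1.5-fold lower number from compound 1 to compound 2 (0.18 log units; within the scatter), is likewise within the scatter. So far, then, changing the halogen or moving it around the ring has not shifted the read-out beyond the usual scatter.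

Compound 4 `CC1CC/C(=N\Nc2ccc(C(F)(F)F)cc2)c2ncc(C(=O)O)c(=O)n21` differs from compound 3 in one place: trifluoromethyl in place of bromo on an aromatic carbon. No measured step exchanges a halogen for trifluoromethyl, so the expectation rests on the three compounds already shown, all of which sit close together. Compound 4 is therefore expected to give 0.8 umol/kg, with a likely range from 0.3 umol/kg to 2.5 umol/kg. This estimate implies no change at the digits printed from compound 3 to compound 4 (within the scatter), a step expected to fall within the scatter rather than beyond it.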

Compound 4, dose for 50% inhibition: 38.6 umol/kg
The estimate for compound 4 lay 48-fold (1.68 log units) below the measured number; the measured number lies above the stated range.
By their numbers in this assay, from the lowest: compounds 2, 1 and 3 (each within the scatter of the next); then compound 4.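

Among the earlier compounds, changing the halogen or moving it on the ring left the read-out within the scatter, but in this assay trifluoromethyl in place of bromo gives a 48-fold higher number from compound 3 to compound 4 (1.68 log units; beyond the scatter). This position, para to a large group, therefore does not accept every substituent equally, and what held for the halogens does not carry over to trifluoromethyl. Nothing available explains this large step.

From the compounds shown here alone, it remains open whether the loss belongs to trifluoromethyl alone or would also appear with other groups at this place, such as methyl, methoxy or a nitrile. Going by these compounds, it is also open how trifluoromethyl would behave at the ring position where compound 1 and compound 2 carry their halogens.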